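Furan-2-yl in place of 2-fluorophenyl: compound 1 to compound 4

A few compounds are considered here, and "the series" means these few. Any claim that something is new, unique, unknown or untested is made for them only; others in the source may bear on it.

In a functional assay on microsomes for inhibition, with a stated time of 1 h (on this read-out lower numbers stand for stronger inhibition and higher numbers for weaker inhibition), compound 1 (`CCOC(=O)c1cnn(-c2nc(-c3ccccc3F)c(C#N)c(=O)n2C)c1N`) gives 94 ug/mL. Compound 2 (`CSc1nc(-c2ccco2)c(C#N)c(=O)n1C`) gives 90 ug/mL, within the scatter of compound 1. Compound 3 (`COc1cccc(-c2nc(NN)n(C)c(=O)c2C#N)c1OC`) gives 37 ug/mL, and its gap to compound 1 lies beyond the scatter. Compound 1 therefore stands level with compound 2 at the weak end of this small set.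

Compound 4 (`CCOC(=O)c1cnn(-c2nc(-c3ccco3)c(C#N)c(=O)n2C)c1N`) is compound 1 with furan-2-yl in place of 2-fluorophenyl on an aromatic carbon. Within the data shown here, no measured pair shows this change on its own, so the expectation rests on indirect evidence. Compound 2 also carries furan-2-yl and gives 90 ug/mL, although it differs from compound 4 elsewhere on the core. No step beyond the scatter is therefore expected in this assay, and the estimated change is small, a 1.2-fold lower number from compound 1 to compound 4 (0.07 log units; within the scatter), towards slightly stronger inhibition if it is real. For compound 4 the expected value is 80 ug/mL, with an estimated range of 38 ug/mL to 160 ug/mL.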

Compound 4, half-maximal inhibitory concentration: 116 ug/mL
Compound 4: middle estimate off by 1.5-fold (0.16 log units), on the low side; the range from low to high includes it.
By their numbers in this assay, from the lowest: compound 3; then compounds 2, 1 and 4 (each within the scatter of the next).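

In this assay, among these compounds, furan-2-yl in place of 2-fluorophenyl gives the first direct reading at this position, next to the ring nitrogen and ortho to a cyano group: a 1.2-fold higher number from compound 1 to compound 4 (0.09 log units; within the scatter). With the rest of compound 1 held fixed, the six-membered carbon ring with its fluorine and the smaller five-membered ring with its oxygen therefore cannot be told apart on this read-out. No measurement shown here bears on why the two rings read alike.

Among the compounds shown here, whether an amine, a carboxylic acid or an unsubstituted phenyl at this position would move the number remains open, since compound 1 and compound 4 are the only pair that differ here alone. Also open, from the compounds shown here alone, is whether the same exchange would read alike if the large group on the shared core were a different one.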